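This account rests on a few compounds, and the source may have more. Where it says the series, first, only, none or still open, it means among the compounds named here.

Compound 3 `Cn1cc(-c2ccc3nnc(Sc4ccc5ncc(NCC6CCOC6)cc5c4)n3c2)cn1` gives 2.4 h in an ADME assay on cytosol from liver for pharmacokinetics, with aldehyde oxidase 1 (Macaca fascicularis) as the target, read by LC-MS, with a stated time of 120 min, tested at 1 uM (a lower number here means that the compound disappears faster, a higher number that the compound lasts longer), the second highest of three numbers. Compound 1 `Cn1cc(-c2ccc3nnc(Sc4ccc5ncc(NC6CCOCC6)cc5c4)n3c2)cn1` gives 4.52 h, and a 1.9-fold lower number from compound 1 to compound 3 (0.27 log units; within the scatter). Compound 2 `Cn1cc(-c2ccc3nnc(Sc4ccc5ncc(NC6COC6)cc5c4)n3c2)cn1` gives 0.05 h, and a 48-fold higher number from compound 2 to compound 3 (1.68 log units; beyond the scatter), while a 90-fold lower number from compound 1 to compound 2 (1.96 log units; beyond the scatter). Compound 4 `Cn1cc(-c2ccc3nnc(Sc4ccc5ncc(N6CCC(N)C6)cc5c4)n3c2)cn1` differs from compound 3 in one place: 3-aminopyrrolidin-1-yl in place of ((oxolan-3-yl)methyl)amino on an aromatic carbon. Among the measured compounds shown here, the measured steps show that this position can move the half-life greatly, but none of them exchanges an ether-bearing amine substituent for 3-aminopyrrolidin-1-yl, so no measured step bears directly on this change. The expectation is therefore loosely anchored on compound 3, with a 1.6-fold lower number from compound 3 to compound 4 (0.20 log units; within the scatter) and a wide range. Compound 4 is expected to give 1.5 h, between 0.15 h and 8 h.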

Compound 4, half-life: > 8.33 h
Compound 4 gave a limit, no number; the forecaster's own chance of this, stated with the estimate: 5%; middle value at least 5.5-fold (0.74 log units) from the limit.
By their numbers in this assay, from the lowest: compound 2; then compounds 3 and 1 (each within the scatter of the next). At a limit, above all of these: compound 4.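

In this assay, compound 4 stands at a limit and not at a number: the limit of > 8.33 h in this assay, at which 1 of the 4 values shown sits. With no oxygen in the entering group, the change still gives an at least 3.4-fold higher number from compound 3 to compound 4 (0.54 log units; beyond the scatter) and an at least 160-fold higher number from compound 2 to compound 4 (2.22 log units; beyond the scatter), so a long half-life at this position does not depend on the ring oxygen that the earlier groups carry. The floor of an at least 1.8-fold higher number from compound 1 to compound 4 (0.26 log units; that floor lies within the scatter) leaves compound 4 and compound 1 unordered. The compounds shown leave open whether the ring amine or the attachment through the ring nitrogen accounts for this, a question that pyrrolidin-1-yl or 3-hydroxypyrrolidin-1-yl would separate.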